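The source may hold more compounds than are shown below. What is called first, only, known or untested is meant among the compounds shown, and "the series" means these compounds.

Three compounds sharing one core have numbers in a functional assay on A549 cells (Homo sapiens) for antiproliferative activity, read by MTT assay, with a stated time of 48 h; a higher number here means a weaker inhibitor, a lower number a stronger inhibitor: compound 1 `COc1ccc(-c2nc3cccc(-c4cc(OC)c(OC)c(OC)c4)c3o2)cc1` gives 2200 nM, compound 2 `COc1cc(-c2cccc3nc(-c4cccc(F)c4)oc23)cc(OC)c1OC` gives 2600 nM, and compound 3 `COc1cc(-c2cccc3nc(-c4ccc(F)cc4)oc23)cc(OC)c1OC` gives 8700 nM. Compound 3 has the highest number of the three, so it is the weakest inhibitor of this small set, and its gaps to both others lie beyond the scatter.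

Compound 4 `COc1cc(-c2cccc3nc(-c4ccc(C)cc4)oc23)cc(OC)c1OC` differs from compound 3 in a single group: methyl in place of fluoro on an aromatic carbon. Put simply, 4-fluorophenyl becomes 4-methylphenyl.

Within the data shown here, no compound with this methyl has been measured, so any forecast must lean on neighbouring changes. The closest is a 4.0-fold higher number from compound 1 to compound 3 (0.60 log units; beyond the scatter), where fluoro takes the place of methoxy on that same ring. The swap of 3-fluorophenyl for 4-fluorophenyl gives a similar rise, a 3.3-fold higher number from compound 2 to compound 3 (0.52 log units; beyond the scatter). Both steps climb towards compound 3, and neither is large. Leaving the fluoro of compound 3 behind may therefore bring the number back down, though probably not all the way.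

In this assay, the expected change is a 2.2-fold lower number from compound 3 to compound 4 (0.34 log units; beyond the scatter), a modest move towards stronger inhibition. The estimate for compound 4 is 4000 nM, with an expected range from 1500 nM to 10000 nM.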

Compound 4, half-maximal inhibitory concentration: 680 nM
Estimate against measurement, compound 4: 5.9-fold (0.77 log units) above; the measured number lies below the stated range.
By their numbers in this assay, from the lowest: compound 4; then compounds 1 and 2 (each within the scatter of the next); then compound 3.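

In this assay a change of just one heavy atom at this spot on the phenyl ring, para to a large group, can matter a great deal: methyl in place of fluoro gives a 13-fold lower number from compound 3 to compound 4 (1.11 log units; beyond the scatter) and is the largest step in the set. Methyl also compares well with the other groups, with a 3.2-fold lower number from compound 1 to compound 4 (0.51 log units; beyond the scatter) when it replaces methoxy and a 3.8-fold lower number from compound 2 to compound 4 (0.58 log units; beyond the scatter) when 4-methylphenyl replaces 3-fluorophenyl, so compound 4 is the strongest inhibitor of the four, whereas the earlier steps had been no more than modest. Nothing measured here accounts for this gain of methyl over fluoro and methoxy.

From the compounds shown here alone, whether a longer chain such as ethyl, a branched group such as tert-butyl, or a chlorine atom in the same place would keep this gain stays open, as does the effect of an amine or a carboxylic acid there. Whether the gain would hold alongside changes elsewhere on the shared core is also unknown.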